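From Chloro to Methoxy: Compound 1 Gives Way to Compound 4

The compounds below may be only part of what the source reports. "The series", "measured", "known", "first", "only" and "open" are said of these compounds alone.

Measured so far:
compound 1 `O=S(=O)(Nc1ccc(-c2nc3ccccc3o2)cc1)c1cccc(Cl)c1` — > 63000 nM
compound 2 `O=S(=O)(Nc1ccc2oc(-c3ccccc3)nc2c1)c1ccccc1C(F)(F)F` — > 63000 nM
compound 3 `O=S(=O)(Nc1ccc2oc(-c3ccccc3)nc2c1)c1ccccc1Cl` — > 63000 nM

In an assay on isolated protein for inhibition of malate dehydrogenase, mitochondrial (Sus scrofa), with stated times of 45 min and 30 min (a lower number here means a stronger inhibitor, a higher number a weaker inhibitor), compound 1 gives only a limit, > 63000 nM. Compound 2 likewise gives only a limit, > 63000 nM. Compound 3 also gives only a limit, > 63000 nM. All three sit together at the limit of > 63000 nM in this assay, at which 3 of the 3 values shown sit, so compound 1 cannot be placed in order against the others. Going by the values given here, the one measured step, a step that the two limits leave unreadable from compound 2 to compound 3, concerns a different place and is unreadable. Compound 4 `COc1cccc(S(=O)(=O)Nc2ccc(-c3nc4ccccc4o3)cc2)c1` arises from compound 1 by methoxy in place of chloro on an aromatic carbon. Among the compounds with values here, no measured step bears on this change, and compound 1 shows only a limit, so compound 4 is expected to stay at the limit, with a step that the limit leaves unreadable from compound 1 to compound 4 not readable. The estimate for compound 4 is 80000 nM, between 30000 nM and 250000 nM.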

Compound 4, half-maximal inhibitory concentration: > 63000 nM
Compound 4 was reported as a limit; the forecaster's own chance of this, stated with the estimate: 85%; the middle value is on the limit's open side.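

Going by these compounds alone, compound 4, like compound 1, is reported only as a limit, so no step between the two can be read: the limit of > 63000 nM in this assay, at which 4 of the 4 values shown sit. The compounds shown leave open what change would give a measured number rather than a limit in this assay.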